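The source may report more compounds than this note shows. Statements on the series, on what has been measured and on what is new or still open speak of the compounds shown alone.

Measured compounds:
- compound 1, `COc1ccc(-c2cc(/C=C/C(=O)c3ccc(N)cc3)[nH]n2)cc1`: 1480 nM
- compound 2, `COc1ccc(C(=O)/C=C/c2cc(-c3cc(OC)c(OC)c(OC)c3)n[nH]2)cc1OC`: 1740 nM

In a functional assay on UACC-62 cells (Homo sapiens) for inhibition, read by sulforhodamine B assay, with a stated time of 48 h (on this read-out higher numbers stand for weaker inhibition of growth and lower numbers for stronger inhibition of growth), compound 1 gives 1480 nM and compound 2 gives 1740 nM. Compound 1 has the lowest of the two numbers, but compound 2 is its nearest neighbour and the gap between the two lies within the usual scatter, so the two are indistinguishable on this assay. Within the data shown here, the two compounds differ in more than one place, so no single step between them can be read.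

Compound 3, `COc1ccc(-c2cc(/C=C/C(=O)c3ccc(N)cc3)[nH]n2)cc1OC`, is not yet measured. It differs from compound 1 by methoxy in place of hydrogen on an aromatic carbon. Among the measured compounds shown here, no measured pair shows the effect of this change on its own. Given that compound 2, which carries several methoxy groups, gives 1740 nM, no step beyond the scatter is expected for the change from compound 1 to compound 3 in this assay, in either direction. The expected step is a 1.0-fold higher number from compound 1 to compound 3 (0.01 log units; within the scatter). Compound 3 is therefore estimated at 1500 nM, with a range from 600 nM to 3800 nM.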

Compound 3, concentration for 50% growth inhibition: 3110 nM
Estimate against measurement, compound 3: 2.1-fold (0.32 log units) below, within the range that was stated.
By their numbers in this assay, from the lowest: compounds 1, 2 and 3 (each within the scatter of the next, the first and the last beyond it).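

In this assay, among these compounds, methoxy in place of hydrogen on an aromatic carbon, ortho to a methoxy group and meta to a large group, gives a 2.1-fold higher number from compound 1 to compound 3 (0.32 log units; beyond the scatter), a modest step towards weaker inhibition of growth and the first change that can be read on its own. Among the compounds shown here, this position on the six-membered aromatic ring of carbon only therefore responds to the change, and a second methoxy group here brings no gain in growth inhibition, though this rests on the single pair of compound 1 and compound 3 and sets no trend for the series. Nothing available explains the step, so it stands as an observation without a cause.

The compounds shown leave open how other groups behave at this same position, such as hydroxy, chlorine or the longer ethoxy chain, and so whether the step is particular to methoxy. They also leave open whether the same change gives a similar step when the amine of compound 1 is replaced by another group, such as a carboxylic acid.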